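Fluorophenyl ketone series: swapping the fluorine position on the aryl

The source may report more compounds than this note shows. Statements on the series, on what has been measured and on what is new or still open speak of the compounds shown alone.

Measured so far:
compound 1, `COc1cc(OC)c(C(=O)c2ccccc2F)c(O)c1CN1CCCC1`: 87%
compound 2, `COc1cc(OC)c(C(=O)c2cccc(F)c2)c(O)c1CN1CCCCC1`: 87%

Both compounds were run in a functional assay on THP-1 cells (Homo sapiens) for inhibition, read by ELISA, with stated times of 30 min and 24 h, tested at 10 uM; a higher number here means a stronger effect of the compound at the concentration tested, a lower number a weaker effect. Compound 1 gives 87% and compound 2 gives 87%; the two stand level at the digits shown, and the pair differs in more than one place, so no single step between them is available. Compound 2 therefore sits at the same level as the only other point in this assay, and the series gives no direction of change so far.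

Compound 3, `COc1cc(OC)c(C(=O)c2ccccc2F)c(O)c1CN1CCCCC1`, is not yet measured. It keeps the rest of compound 2 and changes only the aryl on the ketone: 2-fluorophenyl in place of 3-fluorophenyl on a carbonyl carbon

The same 2-fluorophenyl on the carbonyl carbon is already present in compound 1, which gives 87% in this assay. With both measured values at one level, the step from compound 2 to compound 3 is expected to stay within the scatter, a number 2 percentage points lower from compound 2 to compound 3 (within the scatter), with no direction preferred. Compound 3 is expected to give 85% in this assay, between 70% and 95%.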

Compound 3, a percentage reported as activity, at one concentration (the size of the read-out at that concentration, not a potency): 84%
Compound 3: middle estimate off by 1 percentage points, on the high side, within the range that was stated.
By their numbers in this assay, from the lowest: compounds 3, 1 and 2 (each within the scatter of the next).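

In this assay, for the compounds shown here, 2-fluorophenyl in place of 3-fluorophenyl on a carbonyl carbon gives a number 3 percentage points lower from compound 2 to compound 3 (within the scatter), the first reading of the fluorine position with the rest of the molecule held constant, and it does not separate the two aryl groups. Going by these compounds alone, compound 3 also provides the first single-place reading of the saturated amine, where piperidin-1-yl in place of pyrrolidin-1-yl on a saturated chain carbon bound to an aromatic carbon gives a number 3 percentage points lower from compound 1 to compound 3 (within the scatter), so these two groups are not separated either. No measurement is available that would explain either result.

These figures give the size of the effect at one concentration only, so whether compounds 1, 2 and 3 would show a stronger or weaker effect at any other concentration remains unresolved. Also open, as far as these compounds go, is whether the read-out in this assay would hold with 4-fluorophenyl or unsubstituted phenyl on the carbonyl carbon, or with morpholine or dimethylamine in place of piperidin-1-yl on the saturated chain carbon.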